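Aryl methyl addition on a chloroanilide series

This account rests on a few compounds, and the source may have more. Where it says the series, first, only, none or still open, it means among the compounds named here.

Compound 1 `CCC(=O)N(c1ccc(Cl)cc1)C1CCCC1N(C)C` is the reference point for the unmeasured analogue. In a functional assay on the whole organism for positive allosteric modulation, with Mus musculus as the target (a lower number here means that less compound is needed, a higher number that more compound is needed for the effect), compound 1 gives 3 mg/kg. Compound 2 `CCC(=O)N(c1cccc(Cl)c1)C1CCCC1N(C)C` has the same atoms joined differently; the difference between the two cores is not broken down here. In this assay compound 2 gives 0.4 mg/kg, so compound 1 needs more compound for the effect than compound 2 does. Compound 3 `CCC(=O)N(c1ccc(C)c(Cl)c1)C1CCCC1N(C)C` differs from compound 2 in one place: methyl in place of hydrogen on an aromatic carbon. In this assay compound 3 gives 1 mg/kg, which makes the step of a 2.5-fold higher number from compound 2 to compound 3 (0.40 log units; beyond the scatter).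

Compound 4 `CCC(=O)N(c1ccc(Cl)c(C)c1)C1CCCC1N(C)C` has not yet been measured. Against compound 1 the change is methyl in place of hydrogen on an aromatic carbon. Within the data shown here, this is the same kind of change as the one from compound 2 to compound 3, not the same: in compound 3 the entering methyl sits ortho to a chloro group and para to a large group, in compound 4 it sits ortho to a chloro group and meta to a large group. Among the measured compounds shown here, the only guide to its size is the measured step, which stays modest and moves toward a higher number.

On that basis compound 4 is expected to give 6 mg/kg in this assay. The expected step is a 2.0-fold higher number from compound 1 to compound 4 (0.30 log units; within the scatter), set because the step of a 2.5-fold higher number from compound 2 to compound 3 (0.40 log units; beyond the scatter) pointed the same way. The expected range for compound 4 runs from 2 mg/kg to 18 mg/kg, wide since the surroundings of the place differ from the measured case.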

Compound 4, dose for half-maximal effect: 2 mg/kg
Beside the measured number, compound 4's estimate is 3.0-fold (0.48 log units) above it; the measured number falls inside the stated range.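

In this assay, methyl in place of hydrogen on an aromatic carbon gives a 1.5-fold lower number from compound 1 to compound 4 (0.18 log units; within the scatter), so on this core the change cannot be told apart from no change at all. Set against the earlier step, the same change does not carry over as a fixed increment from one core to the other: the same change on two cores in this assay, a 2.5-fold higher number (0.40 log units; beyond the scatter) from compound 2 to compound 3 and a 1.5-fold lower number (0.18 log units; within the scatter) from compound 1 to compound 4, 3.8-fold (0.57 log units) apart, beyond the scatter of two such steps. Among these compounds, with only one step on each core, this does not show whether the gap follows from the core itself or from the surroundings of the methyl, which in compound 4 sits ortho to a chloro group and meta to a large group, and two steps do not set a rule for any further core.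

The compounds shown leave open whether a different group on this aromatic carbon, such as a methoxy or a fluoro group, would follow the methyl on either core. Also open, as far as these compounds go, is how this assay would respond to a longer chain on the carbonyl, or to a secondary amine in place of the dimethylamino group, on the cores of compound 1 and compound 2.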